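Series notes: piperazine amides, step from compound 3 to compound 4

A few compounds are considered here, and "the series" means these few. Any claim that something is new, unique, unknown or untested is made for them only; others in the source may bear on it.

Measured so far:
compound 1 `Cc1nc(C)c(CN2CCN(C(=O)C(C)(C)Oc3ccc(Cl)cc3)CC2)nc1C` — in a functional assay on ECV-304 cells (Homo sapiens), with stated times of 30 min and 6 h (a higher number here means that more compound is needed for the effect, a lower number that less compound is needed), compound 1 gives "not determined" (no result reported)
compound 2 `COc1cc(/C=C(\C(C)=O)C(=O)N2CCN(Cc3nc(C)c(C)nc3C)CC2)ccc1O` — in this assay compound 2 gives "not determined" (no result reported)
compound 3 `Cc1nc(C)c(CN2CCN(C(=O)CCc3ccccc3)CC2)nc1C` — in this assay compound 3 gives 150000 nM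

Compound 1 and compound 2 carry no number in this assay, so they give no footing for comparison. Compound 3 therefore stands alone: in this assay compound 3 gives 150000 nM, a weak effect, and it is the only measured point on which anything can be built.

Compound 4 `Cc1nc(C)c(CN2CCN(C(=O)CCl)CC2)nc1C` differs from compound 3 in one place: chloro in place of benzyl on a saturated chain carbon bound to a carbonyl carbon. For the measured compounds named here, no step between two measured compounds exists here, so the size and direction of this change cannot be read from the data. With a single weak starting value, the expectation is a step from compound 3 to compound 4 that stays within or close to the usual scatter, a 1.3-fold lower number from compound 3 to compound 4 (0.10 log units; within the scatter), with no firm direction. On that basis compound 4 is estimated at 120000 nM in this assay, with a range from 25000 nM to 600000 nM; a reported limit rather than a number is also a real possibility for compound 4.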

Compound 4, half-maximal effective concentration: 148000 nM
The estimate for compound 4 lay 1.2-fold (0.09 log units) below the measured number; low and high end bracket the measured number.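

For the compounds shown here, replacing benzyl with chloro on a saturated chain carbon bound to a carbonyl carbon gives, in this assay, a 1.0-fold lower number from compound 3 to compound 4 (0.01 log units; within the scatter), the first step that can be read. At this place, then, the aromatic ring of the benzyl group can be lost and a single chlorine atom put in its stead without the number moving beyond the scatter, so this pair shows no dependence of the read-out on that ring. No measurement at hand bears on what lies behind this flat result.

Steps involving compound 1 and compound 2 cannot be read, so the acyl groups of those two compounds add nothing to this picture. Going by these compounds, whether an amine, a carboxylic acid or a longer alkyl chain at this place would shift the number beyond the scatter remains open.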